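From chloro to propyl at the assay limit

The source may report more compounds than this note shows. Statements on the series, on what has been measured and on what is new or still open speak of the compounds shown alone.

Compound 1 `C/C(=N\O)c1ccc(OCc2ccc(C(=O)NO)cc2)cc1`: 7770 nM
Compound 2 `Nc1ccccc1NC(=O)c1ccc(CN2CCc3cc(Br)ccc32)cc1`: 10700 nM
Compound 3 `Nc1ccccc1NC(=O)c1ccc(COc2ccc(Cl)cc2)cc1`: > 32000 nM

All three compounds were tested in a functional assay on HepG2 cells (Homo sapiens) for antiproliferative activity, read by CCK-8 assay, with a stated time of 72 h; a lower number here means a stronger inhibitor, a higher number a weaker inhibitor. Compound 3 gives > 32000 nM, which is a limit of the assay and not a number. Among the three compounds, the record shows (the limit of > 32000 nM in this assay, at which 1 of the 3 values shown sits). Compound 1 and compound 2 both returned numbers.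

Compound 4 `CCCc1ccc(OCc2ccc(C(=O)Nc3ccccc3N)cc2)cc1` keeps the rest of compound 3 but carries propyl in place of chloro on an aromatic carbon, para to a large group: propyl in place of chloro on an aromatic carbon. Within the data shown here, no measured pair shows what this exchange does. A modest step towards a lower number is therefore expected, and compound 4 may also stay at the limit. That expectation leans on the compound closer in structure to compound 3 than compound 1 is, namely compound 2, which gives 10700 nM. The expected change is an at least 1.2-fold lower number from compound 3 to compound 4 (0.10 log units; that floor lies within the scatter). The estimated value for compound 4 is 25000 nM, with an expected range of 9000 nM to 50000 nM.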

Compound 4, half-maximal inhibitory concentration: 4750 nM
Beside the measured number, compound 4's estimate is 5.3-fold (0.72 log units) above it; the measured number lies below the stated range.
By their numbers in this assay, from the lowest: compounds 4, 1 and 2 (each within the scatter of the next, the first and the last beyond it). At a limit, above all of these: compound 3.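

In this assay, propyl in place of chloro on an aromatic carbon, para to a large group, gives a measured number where the chloro compound gave none, with an at least 6.7-fold lower number from compound 3 to compound 4 (0.82 log units; beyond the scatter). Among these compounds, the earlier compounds held no pair differing in one place, so this is the first reading of any change at this position, and it shows that the position responds to the exchange of its substituent. Compound 3 sits at a limit of the assay, so the step gives only a floor for the change and not its full size: the limit of > 32000 nM in this assay, at which 1 of the 4 values shown sits.

The compounds shown do not tell whether a butyl chain, a methyl group, an amine or a carboxylic acid at this same place would move the number further or back. They also leave open whether the same exchange would have a like result on the core of compound 1 or compound 2.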